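Replacing a Cyclopropylbutyl Chain with a Methoxymethylpropyl Chain

The compounds below may be only part of what the source reports. "The series", "measured", "known", "first", "only" and "open" are said of these compounds alone.

Measured compounds:
- compound 1, `COc1ccc(-c2ncnc3c2nc(C)c(=O)n3C(C2CC2)C2CC2)c(C)c1`: 37 nM
- compound 2, `CC[C@@H](C1CC1)n1c(=O)c(C)nc2c(-c3ccc(Cl)cc3Cl)nccc21`: 55 nM
- compound 3, `CCCC(C1CC1)n1c(=O)c(C)nc2c(-c3ccc(Cl)cc3Cl)ccnc21`: 4.3 nM

In a functional assay for antagonist activity at corticotropin-releasing factor receptor 1 (Rattus norvegicus) (on this read-out lower numbers stand for stronger inhibition and higher numbers for weaker inhibition), compound 3 stands at the lowest number of the three, and its gaps to compound 1 and to compound 2 both lie beyond the usual scatter. Compound 4, `CC[C@H](COC)n1c(=O)c(C)nc2c(-c3ccc(Cl)cc3Cl)ccnc21`, is not yet measured. It differs from compound 3 in one place: 1-(methoxymethyl)propyl in place of 1-cyclopropylbutyl on an aromatic nitrogen. Among the measured compounds shown here, no pair among the measured compounds differs only in this way, so the size of this step is not known from the data. The chain that enters is shorter, carries no ring and brings one acceptor, which is a change without a measured counterpart here. The account therefore expects a modest move towards weaker inhibition in this assay, a step from compound 3 to compound 4 estimated as a 3.5-fold higher number from compound 3 to compound 4 (0.54 log units; beyond the scatter), with the possibility that it stays within the scatter. For compound 4 the estimated value in this assay is 15 nM, expected to lie between 4 nM and 60 nM.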

Compound 4, half-maximal inhibitory concentration: 4 nM
Compound 4: the middle estimate sits 3.8-fold (0.57 log units) above what was measured; low and high end bracket the measured number.
By their numbers in this assay, from the lowest: compounds 4 and 3 (each within the scatter of the next); then compounds 1 and 2 (each within the scatter of the next).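

In this assay, 1-(methoxymethyl)propyl in place of 1-cyclopropylbutyl on the aromatic nitrogen gives a step with no difference beyond the scatter (a 1.1-fold lower number from compound 3 to compound 4 (0.03 log units; within the scatter)). This is the first comparison among these compounds that isolates this position, and it shows that, on this core, neither the three-membered ring nor the full length of the butyl chain is required for the read-out to hold, even with a hydrogen-bond acceptor in the entering chain and a defined stereocentre. Nothing at hand explains why the two chains read alike.

The compounds shown leave open whether the result would hold for the opposite configuration at that stereocentre, or with a hydroxyl or an amine in place of the methoxy group. They also leave open whether the same exchange would behave alike on the cores of compound 1 and compound 2.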